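Dimethylamino to methyl: the step to compound 4

The source may report more compounds than this note shows. Statements on the series, on what has been measured and on what is new or still open speak of the compounds shown alone.

Measured so far in a functional assay on HeLa cells (Homo sapiens) for cytotoxicity, read by MTT assay, with a stated time of 2 days; on this read-out higher numbers stand for weaker inhibition and lower numbers for stronger inhibition:
- compound 1 `Cc1ccc2c(=O)[nH]c(-c3cccc(F)c3)nc2c1`: > 50000 nM (a limit)
- compound 2 `CCN(CC)c1ccc2nc(-c3ccccc3N(C)C)[nH]c(=O)c2c1`: 70 nM
- compound 3 `Cc1ccc2nc(-c3ccccc3N(C)C)[nH]c(=O)c2c1`: 14000 nM

Compound 3 stands at the highest of the two numbers; its nearest neighbour is compound 2, and the change between them is a 200-fold higher number from compound 2 to compound 3 (2.30 log units; beyond the scatter). For compound 1 only a limit of this assay is known, (the limit of > 50000 nM in this assay, at which 1 of the 3 values shown sits), so it does not enter the comparison as a number.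

Compound 4 `Cc1ccc2nc(-c3ccccc3C)[nH]c(=O)c2c1` differs from compound 3 by methyl in place of dimethylamino on an aromatic carbon.

No measured step touches this position: the only step shown, a 200-fold higher number from compound 2 to compound 3 (2.30 log units; beyond the scatter), concerns the group on the shared core, not the group ortho to the large group on the six-membered aromatic ring of carbon only. Compounds 2 and 3 both carry dimethylamino there; compound 1, the only one without it, carries a different ring and sits at the limit. An increase is therefore expected, a 2.9-fold higher number from compound 3 to compound 4 (0.46 log units; beyond the scatter), with a real chance that only a limit is returned. Compound 4 is estimated at 40000 nM, within 8000 nM to 200000 nM.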

Compound 4, half-maximal inhibitory concentration: 4580 nM
Estimate against measurement, compound 4: 8.7-fold (0.94 log units) above; measured number outside the range, below it.
By their numbers in this assay, from the lowest: compound 2; then compound 4; then compound 3. At a limit, above all of these: compound 1.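

In this assay, methyl in place of dimethylamino on an aromatic carbon ortho to a large group gives a 3.1-fold lower number from compound 3 to compound 4 (0.49 log units; beyond the scatter), so a dimethylamino group at this place is not needed for a measurable number in this pair. The change is modest beside a 200-fold higher number from compound 2 to compound 3 (2.30 log units; beyond the scatter), which falls on the group on the shared core, so among the steps shown that group has the larger effect on the number. Nothing given here accounts for the direction of the step from dimethylamino to methyl.

Open, on these data alone, is how methyl at this place behaves together with diethylamino on the shared core. Also open, as far as these compounds go, is whether a methoxy group, a primary amine or a plain hydrogen at this place would follow methyl or dimethylamino.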